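The source may hold more compounds than are shown below. What is called first, only, known or untested is meant among the compounds shown, and "the series" means these compounds.

In a functional assay on PC-3 cells (Homo sapiens) for cytotoxicity, read by MTT assay, with a stated time of 48 h (on this read-out higher numbers stand for weaker inhibition and lower numbers for stronger inhibition), compound 1 `O=C(O)CN1C(=O)/C(=C/c2nc3ccccc3n2Cc2ccc([N+](=O)[O-])cc2)SC1=S` gives 8270 nM. Compound 3 `O=C(O)CN1C(=O)/C(=C/c2nc3ccccc3n2Cc2ccc(Cl)cc2)SC1=S` gives 9670 nM, which is level with it, as a 1.2-fold higher number from compound 1 to compound 3 (0.07 log units; within the scatter) shows. Compound 2 `Cc1ccc(Cn2c(/C=C3\SC(=S)N(CC(=O)O)C3=O)nc3ccccc32)cc1` gives 2640 nM, and a 3.1-fold lower number from compound 1 to compound 2 (0.50 log units; beyond the scatter) sets it apart. Compound 4 `O=C(O)CN1C(=O)/C(=C/c2nc3ccccc3n2Cc2ccccc2F)SC1=S` differs from compound 1 as follows: 2-fluorophenyl in place of 4-nitrophenyl on a saturated chain carbon bound to an aromatic nitrogen. In short, 2-fluorophenyl stands in place of 4-nitrophenyl on a saturated chain carbon bound to an aromatic nitrogen. The nearest evidence is these two steps and a 3.7-fold higher number from compound 2 to compound 3 (0.56 log units; beyond the scatter), all exchanges on an aromatic carbon, and none involves a fluoro group. They suggest no step beyond the scatter in this assay, with a modest fall possible. The expected outcome is a 1.3-fold lower number from compound 1 to compound 4 (0.10 log units; within the scatter). Compound 4 is estimated at 6500 nM, with an expected range of 2500 nM to 15000 nM.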

Compound 4, half-maximal inhibitory concentration: 1860 nM
For compound 4 the middle estimate is 3.5-fold (0.54 log units) above the measured one; the measured number lies below the stated range.
By their numbers in this assay, from the lowest: compounds 4 and 2 (each within the scatter of the next); then compounds 1 and 3 (each within the scatter of the next).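

In this assay the change to 2-fluorobenzyl at this position gives a 4.4-fold lower number from compound 1 to compound 4 (0.65 log units; beyond the scatter) and a 5.2-fold lower number from compound 3 to compound 4 (0.72 log units; beyond the scatter), so a replacement of the whole 4-substituted benzyl group moves the number further than the earlier exchanges did. Against the 4-methylphenyl group it gives a 1.4-fold lower number from compound 2 to compound 4 (0.15 log units; within the scatter), which places compound 4 level with compound 2. Nothing measured here bears on why the number falls. The compounds shown leave open whether the fluoro group itself or its place in 2-fluorophenyl carries this step. From the compounds shown here alone, how a 4-fluorobenzyl, a methoxy or an amine on the benzyl group would read also remains open.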